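Swapping Nitro for Cyano: What to Expect in Cell Growth

This account rests on a few compounds, and the source may have more. Where it says the series, first, only, none or still open, it means among the compounds named here.

Of the compounds shown here, three have been measured in a functional assay on VCaP cells (Homo sapiens) for antiproliferative activity, read by propidium iodide staining, with a stated time of 96 h; on this read-out higher numbers stand for weaker inhibition and lower numbers for stronger inhibition. Compound 1 `CC(O)(CS(=O)(=O)c1cccc(S(F)(F)(F)(F)F)c1)C(=O)Nc1ccc(C#N)cc1C(F)(F)F` gives 20800 nM. Compound 2 `CC(O)(CS(=O)(=O)c1cccc(S(F)(F)(F)(F)F)c1)C(=O)Nc1ccc([N+](=O)[O-])cc1C(F)(F)F` gives 100000 nM. Compound 3 `CC1(C)C(=O)N(c2ccc([N+](=O)[O-])c(C(F)(F)F)c2)C(=S)N1c1cccc(S(F)(F)(F)(F)F)c1` gives 100000 nM, level with compound 2 at the digits given. Compound 1 and compound 2 share one core and differ by cyano in place of nitro on an aromatic carbon; this change brings a 4.8-fold lower number from compound 2 to compound 1 (0.68 log units; beyond the scatter). The difference between the core of compound 2 and the core of compound 3 is not broken down here.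

Compound 4 `CC1(C)C(=O)N(c2ccc(C#N)c(C(F)(F)F)c2)C(=S)N1c1cccc(S(F)(F)(F)(F)F)c1` has not yet been tested. It differs from compound 3 by cyano in place of nitro on an aromatic carbon. For the measured compounds named here, this is the same kind of change as the one from compound 2 to compound 1, not the same: in compound 1 the cyano sits meta to a trifluoromethyl group, in compound 4 ortho to a trifluoromethyl group. Going by the values given here, only a single earlier example of this swap exists, so the expectation rests on it alone, because the swap on the other core gave a 4.8-fold lower number from compound 2 to compound 1 (0.68 log units; beyond the scatter). Compound 4 is therefore expected to give about 20000 nM, most likely between 5000 nM and 100000 nM. The expected step is a 5.0-fold lower number from compound 3 to compound 4 (0.70 log units; beyond the scatter).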

Compound 4, half-maximal inhibitory concentration: 100000 nM
Compound 4: the middle estimate sits 5.0-fold (0.70 log units) below what was measured; the measured number falls inside the stated range.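

In this assay, the swap of nitro for cyano on the core of compound 3 gives no change at the digits printed from compound 3 to compound 4 (within the scatter), so the lower number seen on the core of compound 1 did not carry over. Set side by side, the two results differ: the same change on two cores in this assay, a 4.8-fold lower number (0.68 log units; beyond the scatter) from compound 2 to compound 1 and no change at the digits printed (within the scatter) from compound 3 to compound 4, 4.8-fold (0.68 log units) apart, beyond the scatter of two such steps. For the compounds shown here, this shows that a result from this swap on one core cannot be assumed to hold on another, but with only two pairs it does not show which difference between the structures decides the outcome, or whether the cyano's place relative to the trifluoromethyl group plays a part.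

Still open, going by these compounds, is whether another group at this place, such as an amine, a carboxylic acid or a chlorine atom, would lower the number on either core. Also open, on these data alone, is whether the same swap on a third core would follow the pattern of compound 1 or that of compound 4.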